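A few compounds are considered here, and "the series" means these few. Any claim that something is new, unique, unknown or untested is made for them only; others in the source may bear on it.

Of the compounds shown here, three built on one shared core have been measured in a functional assay on PC-3 cells (Homo sapiens) for inhibition, read by sulforhodamine B assay, with a stated time of 48 h; a higher number here means a weaker inhibitor, a lower number a stronger inhibitor. Compound 1 `CC[C@H](C)C(=O)O[C@H]1C[C@@H](C)C=C2C=C[C@H](C)[C@H](CC[C@@H](O)C[C@@H](CC(=O)NO)OC(C)=O)[C@H]21` carries a methyl on the carbonyl carbon of its ester and gives 11400 nM. Compound 2 `CC[C@H](C)C(=O)O[C@H]1C[C@@H](C)C=C2C=C[C@H](C)[C@H](CC[C@@H](O)C[C@@H](CC(=O)NO)OC(=O)c3ccccc3)[C@H]21` carries a phenyl in that place and gives 3300 nM. Compound 3 `CC[C@H](C)C(=O)O[C@H]1C[C@@H](C)C=C2C=C[C@H](C)[C@H](CC[C@@H](O)C[C@@H](CC(=O)NO)OC(=O)c3ccc(Cl)cc3)[C@H]21` carries a 4-chlorophenyl there and gives 21700 nM. Among these three, compound 2 holds the lowest number: the step of a 3.5-fold lower number from compound 1 to compound 2 (0.54 log units; beyond the scatter) and the step of a 6.6-fold higher number from compound 2 to compound 3 (0.82 log units; beyond the scatter) both end further from compound 2 than the scatter allows, while the step of a 1.9-fold higher number from compound 1 to compound 3 (0.28 log units; within the scatter) stays within it.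

Compound 4 `CC[C@H](C)C(=O)O[C@H]1C[C@@H](C)C=C2C=C[C@H](C)[C@H](CC[C@@H](O)C[C@@H](CC(=O)NO)OC(=O)c3ccc4ccccc4c3)[C@H]21` has not yet been measured. It differs from compound 2 in one place: naphthalen-2-yl in place of phenyl on a carbonyl carbon. The two measured steps that touch compound 2 point in opposite directions. Replacing methyl with phenyl lowered the number, as the step from compound 1 to compound 2 shows, whereas adding a chloro to that phenyl raised it, as the step from compound 2 to compound 3 shows. Enlarging the phenyl to a naphthalen-2-yl is therefore expected to give a modest step in this assay, most likely to a somewhat higher number, estimated as a 1.7-fold higher number from compound 2 to compound 4 (0.22 log units; within the scatter). For compound 4 the expected value is 5500 nM, with a range from 1500 nM to 20000 nM.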

Compound 4, half-maximal inhibitory concentration: 17300 nM
The estimate for compound 4 lay 3.1-fold (0.50 log units) below the measured number; low and high end bracket the measured number.
By their numbers in this assay, from the lowest: compound 2; then compounds 1, 4 and 3 (each within the scatter of the next).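

In this assay, replacing the phenyl on the carbonyl carbon with a naphthalen-2-yl, which brings a second six-membered aromatic ring of carbon only, gives a 5.2-fold higher number from compound 2 to compound 4 (0.72 log units; beyond the scatter), so the phenyl ester now loses ground to two larger groups rather than to the 4-chlorophenyl alone. The naphthalen-2-yl ester does not separate from the other two esters, since a 1.3-fold lower number from compound 3 to compound 4 (0.10 log units; within the scatter) and a 1.5-fold higher number from compound 1 to compound 4 (0.18 log units; within the scatter) both stay within the scatter, which leaves compound 2, with its unsubstituted phenyl, as the only one of the four set apart at this position and the strongest inhibitor among them. Nothing shown here gives a measured reason why the unsubstituted phenyl stands apart from the methyl, the 4-chlorophenyl and the naphthalen-2-yl.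

Going by these compounds, it remains open whether a phenyl carrying a smaller group, such as a fluoro or a methoxy, would stay with compound 2 or join the other three. Also open, on these data alone, is how a ring containing nitrogen, such as a pyridinyl, or a saturated ring, such as a cyclohexyl, would behave on the same carbonyl carbon.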